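Thienyl-free aminopyridopyrimidine series: side-chain swap to benzyl

A few compounds are considered here, and "the series" means these few. Any claim that something is new, unique, unknown or untested is made for them only; others in the source may bear on it.

Measured so far in a functional assay on MCF7 cells (Homo sapiens) for cytotoxicity, read by MTT assay, with a stated time of 72 h; a higher number here means a weaker inhibitor of growth, a lower number a stronger inhibitor of growth:
compound 1 `CSc1ccc(CNc2nc(SC)nc3ncccc23)cc1` gives 50 nM
compound 2 `CSc1nc(NCCCCCO)c2cccnc2n1` gives 48900 nM

Compound 2 has the highest number of the two and the gap to compound 1 lies well beyond the scatter, so on the present evidence compound 2 is the weaker of the pair in this assay. Among the measured compounds shown here, no single-point step between the two measured compounds has been counted, so the comparison rests on the two values alone.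

Compound 3 `CSc1nc(NCc2ccccc2)c2cccnc2n1` is the next entry. Relative to compound 2 the change is phenyl in place of 4-hydroxybutyl on a saturated chain carbon bound to a nitrogen on an aromatic ring. The side chain of compound 3 thus carries a ring directly on the chain carbon, in line with compound 1 rather than with compound 2. Because compound 1 reaches 50 nM while compound 2 sits at 48900 nM, the step from compound 2 to compound 3 is expected to be large and toward lower numbers, estimated at a 200-fold lower number from compound 2 to compound 3 (2.29 log units; beyond the scatter), well beyond the scatter. Compound 3 is accordingly expected to give about 250 nM in this assay, within a range of 40 nM to 2500 nM.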

Compound 3, concentration for 50% growth inhibition: 39400 nM
Beside the measured number, compound 3's estimate is 160-fold (2.20 log units) below it; the measured number lies above the stated range.
By their numbers in this assay, from the lowest: compound 1; then compounds 3 and 2 (each within the scatter of the next).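

In this assay, phenyl in place of 4-hydroxybutyl on a saturated chain carbon bound to a nitrogen on an aromatic ring gives a 1.2-fold lower number from compound 2 to compound 3 (0.09 log units; within the scatter) and so does not separate the two compounds; a ring on the chain carbon does not by itself bring the low number of compound 1. The step that does separate two compounds is hydrogen in place of methylsulfanyl on an aromatic carbon, which gives a 790-fold higher number from compound 1 to compound 3 (2.90 log units; beyond the scatter) and ties the low number of compound 1 to the methylsulfanyl group that compound 3 lacks, within this one pair. Nothing on hand gives a reason for either step.

Still open, as far as these compounds go, is whether methoxy, chlorine or methyl on that aromatic carbon would keep the number close to that of compound 1 or whether the methylsulfanyl group has to stay. Also open, from the compounds shown here alone, is how an amine in place of the methylsulfanyl group on the shared core, or a longer chain carrying the substituted phenyl ring, would read in this assay.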